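Dropping a Carbon from the Chain of Compound 3

The source may report more compounds than this note shows. Statements on the series, on what has been measured and on what is new or still open speak of the compounds shown alone.

Compound 3, `CCC(C(=O)N1CCN(c2cccc(F)c2)CC1)N1C(=O)CCC1=O`, is tested in a functional assay on the whole organism (strain Swiss) with Mus musculus as the target, in the maximal electroshock model, with a stated time of 0.5 h, at a dose of 300 mg/kg by the intraperitoneal route (on this read-out lower numbers stand for a weaker effect and higher numbers for a stronger effect at the one dose given), where compound 3 gives 100%. Compound 1, `CC(C(=O)N1CCN(c2ccc(Cl)cc2)CC1)N1C(=O)CCC1=O`, in this assay gives 100%, so compound 3 is level with compound 1 at the digits shown. Compound 2, `CCC(C(=O)N1CCN(c2cccc(OC)c2)CC1)N1C(=O)CCC1=O`, in this assay gives 0%, and the step of a number 100 percentage points higher from compound 2 to compound 3 (beyond the scatter) is large and beyond the scatter.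

Compound 4, `CC(C(=O)N1CCN(c2cccc(F)c2)CC1)N1C(=O)CCC1=O`, has not yet been measured in this assay. It differs from compound 3 by hydrogen in place of methyl on a saturated chain carbon, two bonds along the chain from an amide-type nitrogen in a ring and a carbonyl carbon.

Going by the values given here, no measured pair shows this change on its own. The step from compound 2 to compound 3 concerns a different part of the molecule and does not bear on it directly. The nearest guide is compound 1, which carries the shorter chain and in this assay gives 100%, level with compound 3. Both compounds with the shorter chain and with the fluoro or chloro aromatic substituent therefore sit at the top of the scale that the read-out allows.

The expectation for compound 4 is therefore a step of no change at the digits printed from compound 3 to compound 4 (within the scatter), that is, none beyond the scatter. Compound 4 is estimated to give 100% in this assay, with a range from 60% to 100%.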

Compound 4, a percentage reported as activity, at one dose (the size of the read-out at that dose, not a potency): 50%
Beside the measured number, compound 4's estimate is 50 percentage points above it; measured number outside the range, below it.
By their numbers in this assay, from the lowest: compound 2; then compound 4; then compounds 1 and 3 (each within the scatter of the next).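

In this assay, going by these compounds alone, the change from ethyl to methyl on the saturated chain carbon can be read on its own for the first time, and it gives a number 50 percentage points lower from compound 3 to compound 4 (beyond the scatter). This chain carbon therefore matters when the aromatic group is 3-fluorophenyl, which compound 1 alone, with its different aromatic group and the shorter chain, could not show. The aromatic group matters too when the chain is held at the shorter length, as 3-fluorophenyl in place of 4-chlorophenyl on an amine nitrogen in a ring gives a number 50 percentage points lower from compound 1 to compound 4 (beyond the scatter), and no measurement shown here accounts for either step.

The compounds shown leave open whether a longer chain, such as propyl, or a ring such as cyclopropyl at this carbon would keep the effect seen with ethyl or lose it. Within the data shown here, they also leave open whether the change from ethyl to methyl would give a step of similar size with 4-chlorophenyl or with an unsubstituted phenyl on the same nitrogen, since this one pair is the only reading of that change.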